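Amide nitrogen substituent: isobutyl to 4-methylphenyl

This account rests on a few compounds, and the source may have more. Where it says the series, first, only, none or still open, it means among the compounds named here.

Compound 3 `C=CC1=C(C(=O)NCC(C)C)C(c2ccc(OC)cc2)OC1` is assessed in a functional assay on A549 cells (Homo sapiens) for cytotoxicity, read by MTT assay, with a stated time of 24 h; a lower number here means a stronger inhibitor, a higher number a weaker inhibitor. In this assay compound 3 returns only a limit, > 100000 nM. Compound 2 `C=CC1=C(C(=O)NCCC)C(c2ccc(OC)cc2)OC1` returns the same kind of limit, > 100000 nM. Compound 1 `C=CC1=C(C(=O)Nc2ccc(C)cc2)C(c2ccc(F)cc2)OC1` likewise returns a limit, > 100000 nM. Thus (the limit of > 100000 nM in this assay, at which 3 of the 3 values shown sit); compound 3 stands where the other two stand, and nothing separates them. Within the data shown here, the one measured step, a step that the two limits leave unreadable from compound 2 to compound 3, is accordingly unreadable. Compound 4 `C=CC1=C(C(=O)Nc2ccc(C)cc2)C(c2ccc(OC)cc2)OC1` carries 4-methylphenyl in place of isobutyl on an amide-type nitrogen. Compound 1 shares the 4-methylphenyl on the amide-type nitrogen with compound 4 and also sits at the limit; no readable step bears on this change. Compound 4 is therefore expected to remain at the limit, with an expected step that the limit leaves unreadable from compound 3 to compound 4 that cannot be read, and an estimate of 150000 nM within 60000 nM to 400000 nM.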

Compound 4, half-maximal inhibitory concentration: > 100000 nM
Compound 4: a limit, no number; the forecaster's own chance of this, stated with the estimate: 85%; the middle value does not contradict the limit.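

Compound 4 sits at the same limit as compound 1, compound 2 and compound 3, so no step among these compounds can be read: the limit of > 100000 nM in this assay, at which 4 of the 4 values shown sit.

The compounds shown leave open whether any group on the amide-type nitrogen gives a numerical value in this assay.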